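Propyl on the Core: Compound 2 to Compound 3

The compounds below may be only part of what the source reports. "The series", "measured", "known", "first", "only" and "open" are said of these compounds alone.

Among the compounds with values here, compound 2 `CCCN(CC1CCOC1)C(=O)c1ccc2oc(NCc3cccc(Cl)c3)nc2c1` and compound 1 `COc1cc(C(=O)NCc2cccc(Cl)c2)cc2nn(CCn3cccn3)cc12` are the two measured members. Within the data shown here, in an assay on isolated protein for inhibition of thyroid hormone receptor beta (Homo sapiens), read by fluorescence, with a stated time of 30 min (on this read-out lower numbers stand for stronger inhibition and higher numbers for weaker inhibition), compound 1 gives 464 nM; in this assay compound 2 gives 214 nM, the lowest of the two numbers, with compound 1 as its only neighbour. Compound 3 `CCCc1cc(C(=O)N(CCC)CC2CCOC2)cc2nc(NCc3cccc(Cl)c3)oc12` is not yet measured; it differs from compound 2 by propyl in place of hydrogen on an aromatic carbon. Among the measured compounds shown here, no step of this kind has been measured, so the expected change is modest, toward a somewhat lower number but possibly not beyond the scatter. For compound 3 the estimated value is 150 nM, between 50 nM and 500 nM, an expected step of a 1.4-fold lower number from compound 2 to compound 3 (0.15 log units; within the scatter).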

Compound 3, half-maximal inhibitory concentration: 957 nM
For compound 3 the middle estimate is 6.4-fold (0.80 log units) below the measured one; the whole stated range lies below it.
By their numbers in this assay, from the lowest: compound 2; then compound 1; then compound 3.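

Propyl in place of hydrogen on this aromatic carbon gives a 4.5-fold higher number from compound 2 to compound 3 (0.65 log units; beyond the scatter) in this assay and this is the first reading of the position. On the core of compound 2, hydrogen here gives the stronger inhibition, so this position does not take propyl without loss, though a single pair says nothing about other groups. Nothing at hand explains the loss. Going by these compounds, whether methyl, a fluorine atom, an amine or a carboxylic acid on this carbon behaves like propyl stays open. Also open, on these data alone, is whether a longer chain would go further in the same direction.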